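Same 4-chlorophenyl change carried onto a second core

The compounds below may be only part of what the source reports. "The series", "measured", "known", "first", "only" and "open" are said of these compounds alone.

Compound 1, `O=C1COc2ccc(-c3cnc(Cl)c(NS(=O)(=O)c4ccc(F)cc4)c3)cc2N1`: in a functional assay on A-375 cells (Homo sapiens) for antiproliferative activity, read by MTT assay, with a stated time of 72 h (a higher number here means a weaker inhibitor, a lower number a stronger inhibitor), compound 1 gives only a limit, > 40000 nM.
Compound 2, `O=C1COc2ccc(-c3cnc(Cl)c(NS(=O)(=O)c4ccc(F)cc4)c3)cc2N1c1ccc(Cl)cc1`: in this assay compound 2 gives 30600 nM.
Compound 3, `O=C1COc2ccc(-c3cnc4ccccc4c3)cc2N1`: in this assay compound 3 gives only a limit, > 40000 nM.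

Compound 4, `O=C1COc2ccc(-c3cnc4ccccc4c3)cc2N1c1ccc(Cl)cc1`, has not been measured. The change from compound 1 to compound 2 is 4-chlorophenyl in place of hydrogen on an amide-type nitrogen in a ring, and the step it made in this assay was an at least 1.3-fold lower number from compound 1 to compound 2 (0.11 log units; that floor lies within the scatter). That step is known only as a floor because of the limit of > 40000 nM in this assay, at which 2 of the 3 values shown sit. How the core of compound 3 differs from the core of compound 1 is not broken down here. The change from compound 3 to compound 4 is the same change, (4-chlorophenyl in place of hydrogen on an amide-type nitrogen in a ring), made on the other core. On that basis the step from compound 3 to compound 4 is expected to be small, an at least 1.1-fold lower number from compound 3 to compound 4 (0.05 log units; that floor lies within the scatter), in the same direction as an at least 1.3-fold lower number from compound 1 to compound 2 (0.11 log units; that floor lies within the scatter), and a limit rather than a number remains quite possible. Compound 4 is therefore estimated at 35000 nM, with a range of 12000 nM to 40000 nM.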

Compound 4, half-maximal inhibitory concentration: > 40000 nM
Compound 4: a limit, no number (the forecaster's own chance of this, stated with the estimate: 55%); middle value at least 1.1-fold (0.05 log units) away from the limit.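

In this assay compound 4 gives only a limit, > 40000 nM. Compound 3 also gives only a limit, so no step from compound 3 to compound 4 can be read, because of one shared ceiling: the limit of > 40000 nM in this assay, at which 3 of the 4 values shown sit.

The compounds shown leave open whether 4-chlorophenyl in place of hydrogen on the amide-type nitrogen changes the number at all on the core of compound 3.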